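Swapping the hydroxyphenyl arm on a shared pyridine-free core

The source may report more compounds than this note shows. Statements on the series, on what has been measured and on what is new or still open speak of the compounds shown alone.

Of the compounds shown here, two built on the same core have been tested in a functional assay on DU-145 cells (Homo sapiens) for inhibition; on this read-out higher numbers stand for weaker inhibition and lower numbers for stronger inhibition. Compound 1 `Oc1ccc(-c2cc(-c3ccccc3C(F)(F)F)cc(-c3cccc(O)c3)n2)cc1` gives 2750 nM. Compound 2 `Oc1cccc(-c2cc(-c3ccccc3OC(F)(F)F)cc(-c3cccc(O)c3)n2)c1` gives 5420 nM, and the two numbers lie within the usual scatter of each other, so neither can be called the stronger inhibitor. Compound 3 `Oc1ccc(-c2cc(-c3ccccc3OC(F)(F)F)cc(-c3cccc(O)c3)n2)cc1` is not yet measured. It differs from compound 2 in one place: 4-hydroxyphenyl in place of 3-hydroxyphenyl on an aromatic carbon. Among the measured compounds shown here, no measured pair shows this change alone, so no step beyond the scatter is expected in this assay . Compound 3 is therefore estimated at 4000 nM, between 1500 nM and 11000 nM, an expected step of a 1.4-fold lower number from compound 2 to compound 3 (0.13 log units; within the scatter).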

Compound 3, half-maximal inhibitory concentration: 7760 nM
Estimate against measurement, compound 3: 1.9-fold (0.29 log units) below; low and high end bracket the measured number.
By their numbers in this assay, from the lowest: compounds 1, 2 and 3 (each within the scatter of the next, the first and the last beyond it).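

In this assay, 4-hydroxyphenyl in place of 3-hydroxyphenyl at this position gives a 1.4-fold higher number from compound 2 to compound 3 (0.16 log units; within the scatter), so this swap leaves the two compounds indistinguishable. Compound 3 also allows a comparison at the other arm: trifluoromethoxy in place of trifluoromethyl gives a 2.8-fold higher number from compound 1 to compound 3 (0.45 log units; beyond the scatter), a modest weakening of inhibition. Nothing available here bears on the reason for either step. Still open, going by these compounds, is how an amine or a methoxy group in place of the hydroxyl on this arm would read, and how a plain methyl would compare with trifluoromethyl.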